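Bromo substitution on two related cores: growth inhibition notes

The source may hold more compounds than are shown below. What is called first, only, known or untested is meant among the compounds shown, and "the series" means these compounds.

Measured in a functional assay on cells (Cancer cell lines, Homo sapiens) for cytotoxicity, read by sulforhodamine B assay, with a stated time of 48 h; on this read-out lower numbers stand for stronger inhibition of growth and higher numbers for weaker inhibition of growth:
Compound 1, `COc1ccc(C2CC(c3ccc4ccccc4c3)=NN2C2=NC(=O)/C(=C3\C(=O)Nc4ccccc43)S2)cc1`: compound 1 gives 360 nM.
Compound 2, `COc1ccc(C2CC(c3ccc4ccccc4c3)=NN2C2=NC(=O)/C(=C3\C(=O)Nc4ccc(Br)cc43)S2)cc1`: compound 2 gives 59 nM.
Compound 3, `CN(C)c1ccc(C2CC(c3ccccc3)=NN2C2=NC(=O)/C(=C3\C(=O)Nc4ccccc43)S2)cc1`: compound 3 gives 270 nM.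

Compound 2 is the bromo analogue of compound 1, the change being (bromo in place of hydrogen on an aromatic carbon). In this assay this change made a 6.1-fold lower number from compound 1 to compound 2 (0.79 log units; beyond the scatter). Compound 3 carries a different core from compound 1; the difference between the two cores is not broken down here, and the two values lie within the scatter of each other.

Compound 4, `CN(C)c1ccc(C2CC(c3ccccc3)=NN2C2=NC(=O)/C(=C3\C(=O)Nc4ccc(Br)cc43)S2)cc1`, is not yet measured. It relates to compound 3 as compound 2 relates to compound 1, through (bromo in place of hydrogen on an aromatic carbon), the same change at the same place. Going by the values given here, a step of similar size is expected for compound 4 because a 6.1-fold lower number from compound 1 to compound 2 (0.79 log units; beyond the scatter) was the result of this change on the core of compound 1, though only that one earlier instance supports the expectation.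

For compound 4 the estimate in this assay is 55 nM, expected to fall between 25 nM and 130 nM. This estimate means an expected 4.9-fold lower number from compound 3 to compound 4 (0.69 log units; beyond the scatter).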

Compound 4, concentration for 50% growth inhibition: 270 nM
Estimate against measurement, compound 4: 4.9-fold (0.69 log units) below; measured number outside the range, above it.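

In this assay, bromo in place of hydrogen on an aromatic carbon gave no change at the digits printed from compound 3 to compound 4 (within the scatter), so the change had no readable effect on the core of compound 3. Set beside the earlier step, the result differs from that on the core of compound 1, and the two outcomes cannot be treated as one transferable effect of the change: the same change on two cores in this assay, a 6.1-fold lower number (0.79 log units; beyond the scatter) from compound 1 to compound 2 and no change at the digits printed (within the scatter) from compound 3 to compound 4, 6.1-fold (0.79 log units) apart, beyond the scatter of two such steps This shows that, within these two pairs, the gain seen on the core of compound 1 does not carry over to the core of compound 3, but with one pair per core and cores that differ in more than one place, it does not show which difference between the cores goes with the loss of the step, nor how the change would behave on any other core.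

Still open, from the compounds shown here alone, is whether chloro or methyl on the same aromatic carbon would follow the result for bromo on either core. Also open, going by these compounds, is how the change behaves on a core that carries only one of the differences between the cores of compound 1 and compound 3.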